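The compounds below may be only part of what the source reports. "The series", "measured", "known", "first", "only" and "open" are said of these compounds alone.

Measured in a functional assay on NCI-H1993 cells (Homo sapiens) for inhibition, read by CCK-8 assay, with a stated time of 72 h; on this read-out higher numbers stand for weaker inhibition and lower numbers for stronger inhibition:
compound 1 `CC(c1cc2cccnc2cc1F)n1cnc2ncc(-c3cnn(C)c3)nc21`: 31.3 nM
compound 2 `CC(c1cc2cccnc2cc1F)n1cnc2ncc(-c3cn[nH]c3)nc21`: 187 nM
compound 3 `CC(c1cc2cccnc2cc1F)n1cnc2ncc(-c3cnn(CCO)c3)nc21`: 175 nM

Compound 3 stands with compound 2, a 1.1-fold lower number from compound 2 to compound 3 (0.03 log units; within the scatter), and apart from compound 1, a 5.6-fold higher number from compound 1 to compound 3 (0.75 log units; beyond the scatter). The next structure is compound 4 `CC(c1cc2cccnc2cc1F)n1cnc2ncc(-c3ccccc3)nc21`, where the change is phenyl in place of 1-(2-hydroxyethyl)-1H-pyrazol-4-yl on an aromatic carbon.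

The measured steps bear on this only indirectly. Within the data shown here, all three alter the group on the pyrazole nitrogen, and no measured compound lacks the pyrazole ring. Removing the methyl of compound 1 gave a 6.0-fold higher number from compound 1 to compound 2 (0.78 log units; beyond the scatter), a modest step and the largest of the three. Among the measured compounds shown here, with no direct precedent for the ring swap, a modest move in this assay toward a higher number is expected, though a result within the scatter remains possible. The expected step is a 2.0-fold higher number from compound 3 to compound 4 (0.30 log units; within the scatter). Compound 4 is estimated at 350 nM, with an expected range from 90 nM to 1300 nM.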

Compound 4, half-maximal inhibitory concentration: 570 nM
Beside the measured number, compound 4's estimate is 1.6-fold (0.21 log units) below it, and the stated range covers the measured number.
By their numbers in this assay, from the lowest: compound 1; then compounds 3 and 2 (each within the scatter of the next); then compound 4.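

At this aromatic carbon, the change now concerns the pyrazole ring itself and not only the group on its nitrogen. In this assay, phenyl gives a 3.3-fold higher number from compound 3 to compound 4 (0.51 log units; beyond the scatter), a 3.0-fold higher number from compound 2 to compound 4 (0.48 log units; beyond the scatter) and an 18-fold higher number from compound 1 to compound 4 (1.26 log units; beyond the scatter), so all three pyrazole compounds have lower numbers than the carbon-only ring, and none of the compounds shown goes against this. Nothing available here explains why the ring swap raises the number or why the step from the 1-methyl-1H-pyrazol-4-yl compound is the largest.

As far as these compounds go, it remains open whether a pyridyl ring at this carbon would stand with the pyrazoles or with phenyl. Also open, from the compounds shown here alone, is whether an ethyl or a 2-methoxyethyl group on the pyrazole nitrogen would stand with compound 1 or with compound 3.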